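A few compounds are considered here, and "the series" means these few. Any claim that something is new, unique, unknown or untested is made for them only; others in the source may bear on it.

Measured so far: compound 1 `CC(C)NCc1ccc(-c2c3ncn(CC4(O)CCN(Cc5ccc(-c6ccco6)cc5Cl)CC4)c(=O)c3nn2C)cc1` with 29.1 nM; compound 2 `Cn1nc2c(=O)n(CC3(O)CCN(Cc4ccc(-c5ccncc5)cc4Cl)CC3)cnc2c1-c1ccc(CN)cc1` with 257 nM; compound 3 `Cn1nc2c(=O)n(CC3(O)CCN(Cc4ccc(-c5ccco5)cc4Cl)CC3)cnc2c1-c1ccc(C(N)=O)cc1` with 80.8 nM, all in an assay on isolated protein for inhibition of ubiquitin carboxyl-terminal hydrolase 7 (Homo sapiens), with stated times of 30 min and 2 h; a lower number here means a stronger inhibitor, a higher number a weaker inhibitor.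

Compound 2 gives the highest of the three numbers in this assay, the nearest being compound 3 and the furthest compound 1. Compound 4 `Cn1nc2c(=O)n(CC3(O)CCN(Cc4ccc(C5CCCO5)cc4Cl)CC3)cnc2c1-c1ccc(CN)cc1` differs from compound 2 by oxolan-2-yl in place of pyridin-4-yl on an aromatic carbon. Going by the values given here, the only single-place step measured, a 2.8-fold higher number from compound 1 to compound 3 (0.44 log units; beyond the scatter), concerns a different part of the molecule and does not bear on this exchange; compound 2 and compound 3 differ in two places at once, so their values alone cannot separate the two changes. Among the compounds with values here, with no step informing this position, the expected step of a 1.2-fold higher number from compound 2 to compound 4 (0.07 log units; within the scatter) is small, in no clear direction. Compound 4 is therefore estimated at 300 nM, within 90 nM to 1000 nM.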

Compound 4, half-maximal inhibitory concentration: 3820 nM
For compound 4 the middle estimate is 13-fold (1.10 log units) below the measured one, outside the stated range (above it).
By their numbers in this assay, from the lowest: compound 1; then compound 3; then compound 2; then compound 4.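

In this assay the substituent on this aromatic carbon, para to a large group and meta to a chloro group, proves far from neutral: oxolan-2-yl in place of pyridin-4-yl gives a 15-fold higher number from compound 2 to compound 4 (1.17 log units; beyond the scatter). The exchange replaces a six-membered aromatic ring with a five-membered non-aromatic one, while the counts of hydrogen-bond acceptors, donors and net charge stay the same. Nothing measured here accounts for this weakening. Ring size and aromaticity change together in this single step, so their shares remain open. An oxan-4-yl group, six-membered and non-aromatic, would separate them.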